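A few compounds are considered here, and "the series" means these few. Any claim that something is new, unique, unknown or untested is made for them only; others in the source may bear on it.

Compound 1, `CCCCCNc1nccnc1C(=O)NCc1ccccc1`, stands at a limit in an ADME assay on MDCK cells (Canis lupus familiaris) for cytotoxicity, read by microscopy, with a stated time of 6 days; on this read-out lower numbers stand for higher toxicity in this test and higher numbers for lower toxicity in this test: it gives >= 20000 nM, a limit of the assay rather than a number. Compound 2, `CCCCCNc1cnc(C(=O)NCc2ccccc2)cn1`, likewise gives only a limit, > 100000 nM. Within the data shown here, both values therefore rest at the limits noted in the limit of >= 20000 nM in this assay, at which 1 of the 2 values shown sits, and (the limit of > 100000 nM in this assay, at which 1 of the 2 values shown sits), and no step between the two can be sized. Compound 3, `CCCCCCNc1nccnc1C(=O)NCc1ccccc1`, differs from compound 1 by methyl in place of hydrogen on a saturated chain carbon, five bonds along the chain from a nitrogen on an aromatic ring. Among the measured compounds shown here, no measured step of this kind exists in the set; the expected change is a number no higher from compound 1 to compound 3 (the limit leaves the size open), nothing beyond the scatter. Compound 3 is estimated at 20000 nM, within 5000 nM to 100000 nM, most likely again reported only as a limit.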

Compound 3, minimum cytotoxic concentration: 100000 nM
For compound 3 the middle estimate is 5.0-fold (0.70 log units) below the measured one; the range from low to high includes it.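

Among these compounds, no step from compound 1 to compound 3 can be read in this assay, because compound 1 stands only at a limit: the limit of >= 20000 nM in this assay, at which 1 of the 3 values shown sits. The compounds shown leave open whether methyl in place of hydrogen on the saturated chain changes this read-out at all.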